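A few compounds are considered here, and "the series" means these few. Any claim that something is new, unique, unknown or untested is made for them only; others in the source may bear on it.

Working notes on the series built on the shared core of compound 1 `O=C(NCC1(c2ccccc2)CCCCC1)Nc1ccccc1`, followed in an assay on microsomes from intestine for inhibition of acyl-CoA:cholesterol acyltransferase (Oryctolagus cuniculus); on this read-out higher numbers stand for weaker inhibition and lower numbers for stronger inhibition. Compound 1 gives 2300 nM. Compound 2 `COc1ccccc1NC(=O)NCC1(c2ccccc2)CCCCC1` gives 270 nM, and compound 3 `CC(C)c1ccccc1NC(=O)NCC1(c2ccccc2)CCCCC1` gives 390 nM. On these numbers compound 3 stands second highest of three, within the scatter of compound 2 and beyond the scatter from compound 1. Compound 4 `CCc1cccc(C(C)C)c1NC(=O)NCC1(c2ccccc2)CCCCC1` differs from compound 3 by ethyl in place of hydrogen on an aromatic carbon. Among the compounds with values here, no measured step adds a second group to a ring already carrying one; the nearest bearings are an 8.5-fold lower number from compound 1 to compound 2 (0.93 log units; beyond the scatter) and a 5.9-fold lower number from compound 1 to compound 3 (0.77 log units; beyond the scatter), both modest lowerings on first substitution, while a 1.4-fold higher number from compound 2 to compound 3 (0.16 log units; within the scatter) shows those two groups within scatter of each other. A further modest lowering is therefore expected for compound 4, a 3.0-fold lower number from compound 3 to compound 4 (0.48 log units; beyond the scatter). Compound 4 is estimated at 130 nM, range 40 nM to 400 nM.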

Compound 4, half-maximal inhibitory concentration: 20 nM
For compound 4 the middle estimate is 6.5-fold (0.81 log units) above the measured one; the whole stated range lies above it.
By their numbers in this assay, from the lowest: compound 4; then compounds 2 and 3 (each within the scatter of the next); then compound 1.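

Ethyl on the aromatic carbon ortho to a large group, on a ring already holding an isopropyl group, gives a 20-fold lower number from compound 3 to compound 4 (1.29 log units; beyond the scatter) in this assay and is a large step. The first substitutions were modest by comparison, at an 8.5-fold lower number from compound 1 to compound 2 (0.93 log units; beyond the scatter) and a 5.9-fold lower number from compound 1 to compound 3 (0.77 log units; beyond the scatter) on the same read-out, so a second group here can count for more than a first. Nothing measured on the cause of this step is available.

From the compounds shown here alone, it remains open whether ethyl alone would give a similar step or depends on the isopropyl group. Going by these compounds, how a propyl chain or an amine would read at this carbon also remains open.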